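Cytotoxicity notes on the ether side-chain variations

The compounds below may be only part of what the source reports. "The series", "measured", "known", "first", "only" and "open" are said of these compounds alone.

Compound 1 `O=C1c2ccccc2N(COCc2ccccc2)S(=O)(=O)N1Cc1ccccc1` and compound 2 `C#CCOCN1c2ccccc2C(=O)N(Cc2ccccc2)S1(=O)=O` share one core and differ only in the group on the saturated chain carbon bound to an oxygen on a saturated carbon. In a functional assay on HeLa cells (Homo sapiens) for cytotoxicity (on this read-out higher numbers stand for lower toxicity in this test and lower numbers for higher toxicity in this test), compound 1 gives only a limit, > 50 ug/mL. In this assay compound 2 likewise gives only a limit, > 50 ug/mL. The step that the two limits leave unreadable from compound 1 to compound 2 therefore cannot be sized; what the two measurements share is the limit of > 50 ug/mL in this assay, at which 2 of the 2 values shown sit. Compound 3 `O=C(OCCOCN1c2ccccc2C(=O)N(Cc2ccccc2)S1(=O)=O)c1ccccc1` is not yet measured and carries (benzoyloxy)methyl in place of ethynyl on a saturated chain carbon bound to an oxygen on a saturated carbon. For the measured compounds named here, the one measured step at this position is unreadable, so it offers no direction for what is expected here, and the expected step that the limit leaves unreadable from compound 2 to compound 3 is estimated to stay within the usual scatter. For compound 3 the estimate in this assay is 60 ug/mL, with a range from 25 ug/mL to 150 ug/mL, most probably reported again as a limit rather than a number.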

Compound 3, half-maximal cytotoxic concentration: 24 ug/mL
Estimate against measurement, compound 3: 2.5-fold (0.40 log units) above; measured number outside the range, below it.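

In this assay this position now gives a readable change: (benzoyloxy)methyl in place of ethynyl gives an at least 2.0-fold lower number from compound 2 to compound 3 (0.31 log units; beyond the scatter), and (benzoyloxy)methyl in place of phenyl gives an at least 2.0-fold lower number from compound 1 to compound 3 (0.31 log units; beyond the scatter). The step between the two earlier compounds cannot be read, so only compound 3 shows that a group on a saturated chain carbon bound to an oxygen on a saturated carbon can move this read-out off the limit. Both readable steps are open-ended, with their true size unknown, and they start from a shared limit: the limit of > 50 ug/mL in this assay, at which 2 of the 3 values shown sit.

Which part of the (benzoyloxy)methyl group goes with the lower number stays open, as its six-membered aromatic ring and its hydrogen-bond acceptors enter together. As far as these compounds go, how a hydroxyl, an amine or a plain longer chain at this place would read in this assay also stays open.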